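The compounds below may be only part of what the source reports. "The series", "measured", "known", "first", "only" and "open" are said of these compounds alone.

Measured compounds:
compound 1 `COc1cc(O)c(C(=O)/C=C/c2ccc(F)cc2)c(OC)c1` gives 34%;
compound 2 `COc1cccc(/C=C/C(=O)c2c(OC)cc(OC)cc2OC)c1` gives 0.9%;
compound 3 `COc1cc(OC)c(C(=O)/C=C/c2ccc(F)cc2)c(OC)c1` gives 0.4%.

In a functional assay on PC-3 cells (Homo sapiens), read by fluorescence and BrdU incorporation, with a stated time of 48 h, tested at 25 uM (on this read-out lower numbers stand for a stronger effect and higher numbers for a weaker effect at the one concentration tested), compound 3 and compound 2 give numbers within the scatter of each other, so the change 3-methoxyphenyl in place of 4-fluorophenyl on a double-bonded chain carbon bound to a double-bonded chain carbon made no difference that can be read, as a number 0.5 percentage points lower from compound 2 to compound 3 (within the scatter) shows. The change (hydrogen in place of methyl on an oxygen on an aromatic ring), by contrast, made a large step: a number 33.6 percentage points higher from compound 3 to compound 1 (beyond the scatter). Compound 4 `COc1cccc(/C=C/C(=O)c2c(O)cc(OC)cc2OC)c1` is not yet measured in this assay. It differs from compound 2 by hydrogen in place of methyl on an oxygen on an aromatic ring, the same change as from compound 3 to compound 1, at the same kind of place. A step of similar size is expected here, namely a number 29.1 percentage points higher from compound 2 to compound 4 (beyond the scatter), because of a number 33.6 percentage points higher from compound 3 to compound 1 (beyond the scatter), though it rests on a single earlier step. Compound 4 is therefore expected to give about 30% in this assay, between 8% and 55%.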

Compound 4, a percentage reported as activity, at one concentration (the size of the read-out at that concentration, not a potency): 9.4%
The estimate for compound 4 lay 20.6 percentage points above the measured number; the range from low to high includes it.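

On the core of compound 2, hydrogen in place of methyl on an oxygen on an aromatic ring gives a number 8.5 percentage points higher from compound 2 to compound 4 (within the scatter) in this assay. The large step seen on the core of compound 3 therefore did not carry over at its full size: the same change on two cores in this assay, a number 33.6 percentage points higher (beyond the scatter) from compound 3 to compound 1 and a number 8.5 percentage points higher (within the scatter) from compound 2 to compound 4, 25.1 percentage points apart, beyond the scatter of two such steps

Across these two pairs, the size of the step depends on the core, so it cannot be transferred as a fixed amount, but two pairs give no rule for other cores and do not show why the steps differ.

The compounds shown leave open what an amine or an ethoxy group would give in place of the methoxy group on either core.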